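A few compounds are considered here, and "the series" means these few. Any claim that something is new, unique, unknown or untested is made for them only; others in the source may bear on it.

In a functional assay on MCF7 cells (Homo sapiens) for antiproliferative activity, read by MTT assay, with a stated time of 24 h (a higher number here means a weaker inhibitor, a lower number a stronger inhibitor), compound 1 `c1ccc(Cc2nnc(Cn3nnc4ccccc43)o2)cc1` gives 258000 nM, compound 2 `Brc1cccc(Cc2nnc(Cn3nnc4ccccc43)o2)c1` gives 269000 nM and compound 3 `Fc1cccc(Cc2nnc(Cn3nnc4ccccc43)o2)c1` gives 357000 nM, so all three lie within the scatter of each other. Compound 4 `Brc1ccc(-c2nnc(Cn3nnc4ccccc43)o2)cc1`, not yet measured, differs from compound 1 by this change: 4-bromophenyl in place of benzyl on an aromatic carbon. For the measured compounds named here, two measured steps bear on it only in part: bromo in place of hydrogen gave a 1.0-fold higher number from compound 1 to compound 2 (0.02 log units; within the scatter), and fluoro in place of hydrogen gave a 1.4-fold higher number from compound 1 to compound 3 (0.14 log units; within the scatter), both within the scatter. Neither replaces benzyl, so the evidence is thin, and no step beyond the scatter is expected in this assay, in either direction. The expected step is a 1.2-fold lower number from compound 1 to compound 4 (0.07 log units; within the scatter). Compound 4 is estimated at 220000 nM, with an expected range of 60000 nM to 500000 nM.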

Compound 4, half-maximal inhibitory concentration: 387000 nM
Compound 4: middle estimate off by 1.8-fold (0.25 log units), on the low side; low and high end bracket the measured number.
By their numbers in this assay, from the lowest: compounds 1, 2, 3 and 4 (each within the scatter of the next).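

Unlike the earlier steps, which changed only a hydrogen on the aromatic ring, this change replaces the whole benzyl group, and in this assay it still gives only a 1.5-fold higher number from compound 1 to compound 4 (0.18 log units; within the scatter). Even this larger swap therefore leaves the number at this position within the scatter, with 4-bromophenyl and benzyl not told apart. No measurement on hand offers an explanation for this. On these data alone, whether an amine or a carboxylic acid on the phenyl ring, or a longer chain in place of benzyl, would shift the number beyond the scatter remains open.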